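The source may report more compounds than this note shows. Statements on the series, on what has been measured and on what is new or still open speak of the compounds shown alone.

Measured in an ADME assay on CCRF-HSB-2 cells (Homo sapiens) for cytotoxicity, with a stated time of 7 days; a higher number here means that more compound is tolerated, a lower number that less compound is tolerated:
- compound 1 `CC(C)CSc1nc(N)nc2c1ncn2/C=C1/CC1(CO)CO`: 60000 nM
- compound 2 `CCCCCCCCOc1nc(N)nc2c1ncn2/C=C1/CC1(CO)CO`: > 20000 nM

Compound 2 gives > 20000 nM in this assay, which is a limit of the assay and not a number. As far as these compounds go, its place therefore stays open.

The next analogue is compound 3 `CN(C)c1nc(N)nc2c1ncn2/C=C1/CC1(CO)CO`, with dimethylamino in place of octyloxy on an aromatic carbon. The substituent changes, while the rest of the structure stays the same.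

For the measured compounds named here, only one measured step bears on this change, also at the same aromatic carbon: a step that the limit leaves unreadable from compound 1 to compound 2. It gives no usable size and no direction, so nothing can be carried over from it. Going by the values given here, the only numerical anchor is compound 1 at 60000 nM, and compound 3 is expected to fall in that general region. There is also a real chance that compound 3 gives another limit of the assay.

No step beyond the scatter can be predicted with confidence, and the expected change is a step that the limit leaves unreadable from compound 2 to compound 3.

For compound 3 the estimated value is 40000 nM, with an expected range from 12000 nM to 100000 nM.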

Compound 3, half-maximal cytotoxic concentration: > 20000 nM
Compound 3 was reported as a limit (the forecaster's own chance of this, stated with the estimate: 45%); the middle value lies beyond the limit too.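

In this assay compound 3 gives > 20000 nM as a limit of the assay and not a number. No new step can be read among compound 1, compound 2 and compound 3: the limit of > 20000 nM in this assay, at which 2 of the 3 values shown sit. The compounds shown leave open where compound 2 and compound 3 stand relative to compound 1 and to each other.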